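Aryl thiocarbamate series: pyridinyl to phenyl swap in compound 4

The compounds below may be only part of what the source reports. "The series", "measured", "known", "first", "only" and "open" are said of these compounds alone.

Compound 1 `S=C(Nc1ccc(Cl)cc1)OCCc1ccccn1` carries a chlorophenyl on the thiocarbamate nitrogen and a pyridin-2-yl at the end of the chain. In an ADME assay on MT4 cells (Homo sapiens) for cytotoxicity, read by MTT assay (on this read-out higher numbers stand for lower toxicity in this test and lower numbers for higher toxicity in this test), compound 1 gives 52000 nM. Compound 2 `S=C(Nc1ccc(Br)cc1)OCCc1ccccn1` gives 37000 nM in this assay, and compound 3 `O=[N+]([O-])c1cc(NC(=S)OCCc2ccccn2)ccc1Cl` gives 41000 nM. The measured steps are small: a 1.4-fold lower number from compound 1 to compound 2 (0.15 log units; within the scatter) and a 1.3-fold lower number from compound 1 to compound 3 (0.10 log units; within the scatter). Compound 1 therefore stands together with compounds 2 and 3, the three numbers sitting within the scatter of one another.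

Compound 4 `S=C(Nc1ccc(Cl)cc1)OCCc1ccccc1` differs from compound 1 in one place: phenyl in place of pyridin-2-yl on a saturated chain carbon, two bonds along the chain from an oxygen on an unsaturated carbon. Within the data shown here, none of the measured steps touches that position; both concern the aryl ring on the nitrogen, and both lie within the scatter. Among the measured compounds shown here, the data give no step that bears on the chain-end ring, so the expectation rests only on the flatness of the series seen so far.

For compound 4 the step is expected to be a 1.0-fold lower number from compound 1 to compound 4 (0.02 log units; within the scatter), that is, no change beyond the scatter. Compound 4 is estimated at 50000 nM in this assay, with an expected range from 20000 nM to 130000 nM.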

Compound 4, half-maximal cytotoxic concentration: > 100000 nM
Compound 4: a limit, no number (the forecaster's own chance of this, stated with the estimate: 15%); middle value at least 2.0-fold (0.30 log units) away from the limit.
By their numbers in this assay, from the lowest: compounds 2, 3 and 1 (each within the scatter of the next). At a limit, above all of these: compound 4.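

In this assay compound 4 gives > 100000 nM, which is a limit of the test and not a number. Phenyl in place of pyridin-2-yl on a saturated chain carbon, swapping a ring with 1 hydrogen-bond acceptor for one with 0, gives an at least 1.9-fold higher number from compound 1 to compound 4 (0.28 log units; that floor lies within the scatter); the floor of this step lies within the scatter, as did the earlier steps, bromo in place of chloro and nitro in place of hydrogen, so no change beyond the scatter is established, but this is the first change in the series to reach the limit of the read-out. The real size of the step stays unknown because the reading ends at a limit: the limit of > 100000 nM in this assay, at which 1 of the 4 values shown sits.

The compounds shown leave open how far the number for compound 4 lies from the limit, and whether bromo or nitro in the phenyl-ended compounds would stay as flat as in the pyridin-2-yl compounds. Also open, as far as these compounds go, is how this position reads with pyridin-4-yl, with an amine such as piperidin-1-yl, or with a longer chain carrying the ring.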